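The source may report more compounds than this note shows. Statements on the series, on what has been measured and on what is new or still open speak of the compounds shown alone.

Measured compounds:
- Compound 1 `Cc1cc(O)cc(-c2nn(CC#N)cc2-c2ccnc(-c3ccc(Oc4ccccc4)cc3)c2)c1`: 91%
- Compound 2 `COc1cc(C)cc(-c2nn(CC#N)cc2-c2ccnc(-c3ccc(N(C)C)cc3)c2)c1`: 90%

In a functional assay on SF-268 cells (Homo sapiens) for cytotoxicity, read by sulforhodamine B assay, with a stated time of 48 h, tested at 0.01 uM (on this read-out higher numbers stand for a weaker effect at the one concentration tested and lower numbers for a stronger effect), compound 1 gives 91% and compound 2 gives 90%. The two numbers sit within the usual scatter of each other, so on this assay compound 2 cannot be told apart from compound 1; both show only a weak effect at the single concentration tested.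

Compound 3 `Cc1cc(O)cc(-c2nn(CC#N)cc2-c2ccnc(-c3ccc(N(C)C)cc3)c2)c1` has not yet been measured. It differs from compound 2 in one place: hydrogen in place of methyl on an oxygen on an aromatic ring. The same hydroxy group is already present in compound 1, which reads very much like compound 2.

Among the compounds with values here, no step between measured compounds is available, so the size of this change has not been seen directly. Because compound 1 gives 91% and compound 2 gives 90%, no step beyond the scatter is expected in this assay. Compound 3 is therefore estimated at 90%, with a range of 80% to 100%. The expected step is no change at the digits printed from compound 2 to compound 3 (within the scatter).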

Compound 3, a percentage reported as activity, at one concentration (the size of the read-out at that concentration, not a potency): 90%
Estimate against measurement, compound 3: no gap at the digits printed, within the range that was stated.
By their numbers in this assay, from the lowest: compounds 2, 3 and 1 (each within the scatter of the next).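

In this assay, hydrogen in place of methyl on this oxygen on an aromatic ring, which turns methoxy into hydroxy, gives no change at the digits printed from compound 2 to compound 3 (within the scatter) and shows directly that this swap leaves the read-out where it was at the one concentration tested. A second single change can now be read too: dimethylamino in place of phenoxy on an aromatic carbon gives a number 1 percentage points lower from compound 1 to compound 3 (within the scatter) and so also produces no step beyond the scatter. Nothing shown explains either result.

From the compounds shown here alone, all three compounds show only a weak effect at one concentration, so it remains open whether these groups would matter at a concentration where the effect is stronger. Also open, going by these compounds, is how a longer chain on this oxygen, such as ethyl, or a carboxylic acid in place of the hydroxy would read.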